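A few compounds are considered here, and "the series" means these few. Any claim that something is new, unique, unknown or untested is made for them only; others in the source may bear on it.

In a functional assay on the whole organism for inhibition, with Rattus norvegicus as the target, with stated times of 1 h and 3.5 h, at a dose of 100 mg/kg by the oral route (a lower number here means less inhibition, a higher number more inhibition at the dose given (going by the name of the read-out)), compound 1 `Cc1cnc(N)nc1-c1ccccc1` gives 34%. Compound 2 `N#CNc1nccc(-c2ccncc2)n1` returns only a limit in this assay, < 5%, and so it stands at the limit of < 5% in this assay, at which 1 of the 2 values shown sits, rather than at a measured number. Compound 3 `CCOC(=O)Nc1nccc(-c2ccncc2)n1` carries ethoxycarbonyl in place of cyano on a nitrogen on an aromatic ring. Among the measured compounds shown here, no measured pair of compounds covers a change of this kind, so the expectation for compound 3 rests on where compound 2 sits and on the usual scatter of this assay. Compound 3 is expected to show 8%, within 0% to 25%. This amounts to an expected step of a number at least 3 percentage points higher from compound 2 to compound 3 (that floor lies within the scatter), a size that stays within the usual scatter.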

Compound 3, a percentage reported as inhibition, in the whole organism at one dose (the size of the read-out at that dose, not a potency): 31%
For compound 3 the middle estimate is 23 percentage points below the measured one, and the stated range ends below it.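

In this assay, ethoxycarbonyl in place of cyano on a nitrogen on an aromatic ring amounts to a number at least 26 percentage points higher from compound 2 to compound 3 (beyond the scatter). Among the compounds shown here, this pair is the first to show that the group on this nitrogen can move the read-out by more than the scatter, with the rest of the structure unchanged. How far the step reaches upward stays open because compound 2 gives only a limit: the limit of < 5% in this assay, at which 1 of the 3 values shown sits.

The compounds shown leave open whether acetyl or a longer chain such as butoxycarbonyl on this nitrogen would give a similar read-out. They also do not separate the part played by the carbonyl from that of the ethyl chain.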